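The compounds below may be only part of what the source reports. "The series", "measured", "known", "first", "only" and "open" are said of these compounds alone.

Measured so far:
- compound 1, `CC1C(=O)N(CCCCCCOc2ccc(Cl)cc2)/C(=N\C#N)N1c1ccncc1`: 333 nM
- compound 2, `CC1C(=O)N(CCCCCCCOc2ccc(Cl)cc2)/C(=N\C#N)N1c1ccncc1`: 370 nM
- compound 3, `N#C/N=C1\N(CCCCCCOc2ccc(Cl)cc2)C(=O)CCN1c1ccncc1`: 565 nM

All three numbers come from a functional assay on DLD-1 cells (Homo sapiens) for cytotoxicity; on this read-out higher numbers stand for weaker inhibition and lower numbers for stronger inhibition.

Compound 2 differs from compound 1 by (4-chlorophenoxy)methyl in place of 4-chlorophenoxy on a saturated chain carbon, six bonds along the chain from an amide-type nitrogen in a ring. The step that this change made is a 1.1-fold higher number from compound 1 to compound 2 (0.05 log units; within the scatter), so the two numbers cannot be told apart. Compound 3 carries a different core; the difference between the two cores is not broken down here. Its number in this assay sits within the usual scatter of both compound 1 and compound 2, so no ordering among the three is claimed.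

Compound 4, `N#C/N=C1\N(CCCCCCCOc2ccc(Cl)cc2)C(=O)CCN1c1ccncc1`, is still to be measured in this assay. Among the measured compounds shown here, it differs from compound 3 by (4-chlorophenoxy)methyl in place of 4-chlorophenoxy on a saturated chain carbon, six bonds along the chain from an amide-type nitrogen in a ring, which is the same change, at the same place, as the one between compound 1 and compound 2. For the measured compounds named here, the only precedent for the change is therefore a 1.1-fold higher number from compound 1 to compound 2 (0.05 log units; within the scatter), a step within the scatter. On that basis the step from compound 3 to compound 4 is expected to be about as small, a 1.1-fold higher number from compound 3 to compound 4 (0.03 log units; within the scatter). Compound 4 is estimated at 600 nM, with a range of 300 nM to 1200 nM, and the number is expected to stay within scatter of compound 3.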

Compound 4, half-maximal inhibitory concentration: 3200 nM
Compound 4: the middle estimate sits 5.3-fold (0.73 log units) below what was measured, outside the stated range (above it).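

In this assay, (4-chlorophenoxy)methyl in place of 4-chlorophenoxy gives a 5.7-fold higher number from compound 3 to compound 4 (0.75 log units; beyond the scatter), so on the core of compound 3 the change has a clear effect, unlike on the core of compound 1. The step therefore does not carry over from one of these cores to the other at one size, and the two steps differ: the same change on two cores in this assay, a 1.1-fold higher number (0.05 log units; within the scatter) from compound 1 to compound 2 and a 5.7-fold higher number (0.75 log units; beyond the scatter) from compound 3 to compound 4, 5.1-fold (0.71 log units) apart, beyond the scatter of two such steps This rests on a single pair per core, so it shows a dependence on the core for these two pairs only, and it does not show which feature of the cores accounts for the gap or how the change would behave on any other core.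

Still open, on these data alone, is whether a longer chain, such as 2-(4-chlorophenoxy)ethyl, would widen or close the gap between the two cores. Also open, as far as these compounds go, is whether an amine in place of 4-chlorophenoxy would give the same outcome on both cores.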